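A few compounds are considered here, and "the series" means these few. Any claim that something is new, unique, unknown or untested is made for them only; others in the source may bear on it.

Compound 1, `Cc1cc(C)c(S(C)(=O)=O)cc1C(=O)N=C(N)N`, is measured in a functional assay for inhibition of sodium/hydrogen exchanger (Oryctolagus cuniculus) (a lower number here means a stronger inhibitor, a higher number a weaker inhibitor), where compound 1 gives 11 nM. Compound 2, `Cc1cc(C2CCCCC2)c(S(C)(=O)=O)cc1C(=O)N=C(N)N`, gives 22 nM in this assay. The two share a core and differ by methyl in place of cyclohexyl on an aromatic carbon; that change gave a 2.0-fold lower number from compound 2 to compound 1 (0.30 log units; within the scatter). Compound 3, `CS(=O)(=O)c1cc(C(=O)N=C(N)N)ccc1C1CCCCC1`, gives 340 nM in this assay, and it stands apart from compound 2 by hydrogen in place of methyl on an aromatic carbon, a change that gave a 15-fold higher number from compound 2 to compound 3 (1.19 log units; beyond the scatter). Compound 4, `Cc1ccc(C(=O)N=C(N)N)cc1S(C)(=O)=O`, has not been measured. It differs from compound 3 by methyl in place of cyclohexyl on an aromatic carbon, the same kind of change as from compound 2 to compound 1, though the surroundings are not identical: from compound 2 to compound 1 the changed carbon was also meta to a methyl group, which is absent around the changed carbon of compound 3 and compound 4. Since the earlier step, a 2.0-fold lower number from compound 2 to compound 1 (0.30 log units; within the scatter), lay within the usual scatter, an equally small step is expected here, a 1.7-fold lower number from compound 3 to compound 4 (0.23 log units; within the scatter). Compound 4 is therefore estimated at 200 nM in this assay, with a range from 70 nM to 600 nM.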

Compound 4, half-maximal inhibitory concentration: 210 nM
Estimate against measurement, compound 4: 1.1-fold (0.02 log units) below, within the range that was stated.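

In this assay, methyl in place of cyclohexyl on an aromatic carbon gave a 1.6-fold lower number from compound 3 to compound 4 (0.21 log units; within the scatter) on the second core, in line with the earlier step: the same change on two cores in this assay, a 2.0-fold lower number (0.30 log units; within the scatter) from compound 2 to compound 1 and a 1.6-fold lower number (0.21 log units; within the scatter) from compound 3 to compound 4, 1.2-fold (0.09 log units) apart, within the scatter of two such steps. Hydrogen in place of methyl on an aromatic carbon gave a 19-fold higher number from compound 1 to compound 4 (1.28 log units; beyond the scatter) and so remained a large step, again in line with the earlier one: the same change on two cores in this assay, a 15-fold higher number (1.19 log units; beyond the scatter) from compound 2 to compound 3 and a 19-fold higher number (1.28 log units; beyond the scatter) from compound 1 to compound 4, 1.2-fold (0.09 log units) apart, within the scatter of two such steps. Both changes therefore carried from one core to the other among these four compounds, but two pairs of steps do not show that either change would keep its size on any further core, and they do not explain the size of either step.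

The compounds shown leave open whether the same steps would hold with another group at the changed carbon, such as an amine, a carboxylic acid or a longer chain. They also leave open whether either step would keep its size if the methylsulfonyl group were replaced by another group, such as a nitrile.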